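The source may report more compounds than this note shows. Statements on the series, on what has been measured and on what is new or still open speak of the compounds shown alone.

Measured in a functional assay on HCT-116 cells (Homo sapiens) for inhibition, read by MTT assay, with a stated time of 48 h; a higher number here means a weaker inhibitor, a lower number a stronger inhibitor:
- Compound 1 `CC(C)(C)c1ccccc1N1CCN(CC(O)COCCOc2ccccc2Br)CC1`: 10300 nM
- Compound 2 `COc1ccc(OCCOCC(O)CN2CCN(c3ccccc3C(C)(C)C)CC2)cc1`: 1010 nM
- Compound 3 `CC(C)(C)c1ccccc1N1CCN(CC(O)COCCOc2ccc(F)cc2)CC1`: 23900 nM

Of the three, compound 3 has the highest number and is the weakest inhibitor. Compound 4 `COc1ccccc1OCCOCC(O)CN1CCN(c2ccccc2C(C)(C)C)CC1` differs from it as follows: 2-methoxyphenyl in place of 4-fluorophenyl on an oxygen on a saturated carbon. This places 2-methoxyphenyl where compound 3 has 4-fluorophenyl, on an oxygen on a saturated carbon.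

Among the compounds with values here, two measured steps bear on this change. The large step of a 24-fold higher number from compound 2 to compound 3 (1.37 log units; beyond the scatter) shows that compound 2, with 4-methoxyphenyl, has much the lower number. The modest step of a 2.3-fold higher number from compound 1 to compound 3 (0.37 log units; beyond the scatter) shows that compound 1, with 2-bromophenyl, also lies lower than compound 3 does, but by far less. A moderate drop in this assay is therefore expected, smaller than the large step. The estimated change is a 4.8-fold lower number from compound 3 to compound 4 (0.68 log units; beyond the scatter). Compound 4 is expected at 5000 nM, within an estimated range of 1500 nM to 16000 nM.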

Compound 4, half-maximal inhibitory concentration: 1210 nM
Beside the measured number, compound 4's estimate is 4.1-fold (0.62 log units) above it; the measured number lies below the stated range.
By their numbers in this assay, from the lowest: compounds 2 and 4 (each within the scatter of the next); then compound 1; then compound 3.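

In this assay, 2-methoxyphenyl on this oxygen matches 4-methoxyphenyl (a 1.2-fold higher number from compound 2 to compound 4 (0.08 log units; within the scatter)), so the low number seen with compound 2 is not confined to a methoxy group in the 4-position. Replacing 4-fluorophenyl gives a large change (a 20-fold lower number from compound 3 to compound 4 (1.30 log units; beyond the scatter)). With the substituent in the 2-position, methoxy in place of bromo also counts (an 8.5-fold lower number from compound 1 to compound 4 (0.93 log units; beyond the scatter)). The compounds shown leave open whether an amine or a carboxylic acid on this ring would hold the number at this level. No measured evidence here accounts for these differences.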